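A few compounds are considered here, and "the series" means these few. Any claim that something is new, unique, unknown or untested is made for them only; others in the source may bear on it.

- Compound 1 `CCCCC(O)CC(=O)O[C@H](CC=C(C)C)C1=CC(=O)c2c(O)ccc(O)c2C1=O`: 45300 nM
- Compound 2 `CCCC(CC(=O)O[C@H](CC=C(C)C)C1=CC(=O)c2c(O)ccc(O)c2C1=O)OC(C)=O`: 55700 nM
- Compound 3 `CC(C)=CC[C@@H](OC(=O)C1CCOC1)C1=CC(=O)c2c(O)ccc(O)c2C1=O`: 47500 nM

In a functional assay on DU-145 cells (Homo sapiens) for cytotoxicity, read by MTT assay (a higher number here means a weaker inhibitor, a lower number a stronger inhibitor), compound 3 stands level with the other two compounds, and all three values lie within the scatter of one another. Compound 4 `CC(C)=CC[C@@H](OC(=O)CC(C)(O)C(C)C)C1=CC(=O)c2c(O)ccc(O)c2C1=O` differs from compound 3 on a carbonyl carbon: 2-hydroxy-2,3-dimethylbutyl in place of oxolan-3-yl on a carbonyl carbon. Among the compounds with values here, two measured steps bear on this exchange of an open chain and oxolan-3-yl. One is a 1.0-fold higher number from compound 1 to compound 3 (0.02 log units; within the scatter), with 2-hydroxyhexyl leaving, and the other is a 1.2-fold lower number from compound 2 to compound 3 (0.07 log units; within the scatter), with 2-acetoxypentyl leaving. Neither exceeds the scatter, so no step beyond it is expected here, though neither chain matches 2-hydroxy-2,3-dimethylbutyl exactly. The expected size is a 1.0-fold higher number from compound 3 to compound 4 (0.00 log units; within the scatter). For compound 4 the estimated value is 48000 nM, with an expected range from 28000 nM to 82000 nM.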

Compound 4, half-maximal inhibitory concentration: 16900 nM
The estimate for compound 4 lay 2.8-fold (0.45 log units) above the measured number; measured number below the stated range.
By their numbers in this assay, from the lowest: compound 4; then compounds 1, 3 and 2 (each within the scatter of the next).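

In this assay the group on the carbonyl carbon now makes a difference beyond the scatter, which no earlier exchange there did: a 2.8-fold lower number from compound 3 to compound 4 (0.45 log units; beyond the scatter) and the open chains give way likewise, with a 3.3-fold lower number from compound 2 to compound 4 (0.52 log units; beyond the scatter) and a 2.7-fold lower number from compound 1 to compound 4 (0.43 log units; beyond the scatter). The branched 1-hydroxy-1,2-dimethylpropyl thus stands apart from both unbranched chains on the saturated chain carbon, not only from the ring. No measurement at hand accounts for this. Still open, from the compounds shown here alone, is whether the lower number follows the branching or the hydroxy group, which a methoxy group on the same branched chain would separate. Going by these compounds, whether an amine or a carboxylic acid here would lower the number further also remains open.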